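Compound 3 and the Exchange of One Group

The source may hold more compounds than are shown below. What is called first, only, known or untested is meant among the compounds shown, and "the series" means these compounds.

In a physicochemical assay for solubility, read by chemiluminescence, in phosphate buffer, measured as kinetic solubility, at pH 7.4 (on this read-out lower numbers stand for lower solubility and higher numbers for higher solubility), compound 3 `O=C(NCC1(c2nc(-c3ccccc3)cs2)CCOCC1)c1ccc(-n2ccnc2)cc1` gives 193000 nM. Compound 1 `O=C(NCC1(c2nc(-c3ccccc3)cs2)CCOCC1)c1ccc(-n2cncn2)cc1` gives 191000 nM, within the scatter of compound 3. Compound 2 `Cc1cc(C)n(-c2ccc(C(=O)NCC3(c4nc(-c5ccccc5)cs4)CCOCC3)cc2)n1` gives 33000 nM, the lowest of the three. Compound 4 `Cn1c(Nc2ccc(C(=O)NCC3(c4nc(-c5ccccc5)cs4)CCOCC3)cc2)nc2ccccc21` is still unmeasured and carries (1-methyl-1H-benzimidazol-2-yl)amino in place of 1H-imidazol-1-yl on an aromatic carbon, para to a large group: (1-methyl-1H-benzimidazol-2-yl)amino in place of 1H-imidazol-1-yl on an aromatic carbon.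

Two measured steps at this same place bear on the change. The step of a 1.0-fold higher number from compound 1 to compound 3 (0.00 log units; within the scatter) stays within the scatter, so exchanging one unsubstituted ring for the other left the number unmoved. Among the compounds with values here, the step of a 5.8-fold lower number from compound 1 to compound 2 (0.76 log units; beyond the scatter) lies beyond the scatter and came with 3,5-dimethyl-1H-pyrazol-1-yl, the only substituted group measured here. The entering group of compound 4 resembles none of these closely, so the guidance is loose, but a downward move somewhat larger than that drop to compound 2 is expected. The expected step is a 13-fold lower number from compound 3 to compound 4 (1.11 log units; beyond the scatter). For compound 4 the estimated value is 15000 nM, with an expected range of 3000 nM to 60000 nM.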

Compound 4, solubility: 10000 nM
The estimate for compound 4 lay 1.5-fold (0.18 log units) above the measured number, within the range that was stated.
By their numbers in this assay, from the lowest: compound 4; then compound 2; then compounds 1 and 3 (each within the scatter of the next).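

In this assay, the (1-methyl-1H-benzimidazol-2-yl)amino group on this aromatic carbon, para to a large group, produced large steps where the earlier exchanges had been at most modest: a 19-fold lower number from compound 3 to compound 4 (1.29 log units; beyond the scatter) and a 19-fold lower number from compound 1 to compound 4 (1.28 log units; beyond the scatter). Within the data shown here, the same group also took the number past that of the only substituted group measured earlier, 3,5-dimethyl-1H-pyrazol-1-yl, with a 3.3-fold lower number from compound 2 to compound 4 (0.52 log units; beyond the scatter). No measurement shown here accounts for these drops.

The change brings in the amino link and the six-membered aromatic ring of carbon only together, so the compounds shown leave open which of them goes with the drop. A 1-methyl-1H-benzimidazol-2-yl group attached without the amino link, or an open amine such as morpholine at this place, would bear on that question.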